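Ring substituent swap: methoxy for 4-methylbenzyl on compound 3

This account rests on a few compounds, and the source may have more. Where it says the series, first, only, none or still open, it means among the compounds named here.

Measured so far in a functional assay on CHO-K1 cells for antagonist activity at transient receptor potential cation channel subfamily V member 1 (Homo sapiens), read by FLIPR; a higher number here means a weaker inhibitor, a lower number a stronger inhibitor:
compound 1 `CC(C(=O)NCc1ccc(C(F)(F)F)nc1N1CCCC1)c1ccc(NS(C)(=O)=O)c(F)c1` gives 0.6 nM
compound 2 `CC(C(=O)NCc1ccc(C(F)(F)F)nc1N1CC=CCC1)c1ccc(NS(C)(=O)=O)c(F)c1` gives 0.3 nM
compound 3 `Cc1ccc(CC2CCN(c3nc(C(F)(F)F)ccc3CNC(=O)C(C)c3ccc(NS(C)(=O)=O)c(F)c3)CC2)cc1` gives 0.2 nM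

Compound 3 holds the lowest number of the three. Its number and that of compound 2 lie within the scatter of each other, so no order between them is claimed; the gap to compound 1 lies beyond the scatter.

Compound 4 `COC1CCN(c2nc(C(F)(F)F)ccc2CNC(=O)C(C)c2ccc(NS(C)(=O)=O)c(F)c2)CC1` is not yet measured. It differs from compound 3 in one place: methoxy in place of 4-methylbenzyl on a saturated ring carbon.

Among the compounds with values here, only one measured step exists, a 2.0-fold lower number from compound 1 to compound 2 (0.30 log units; within the scatter), and it concerns the size of the non-aromatic ring on the aromatic carbon, not a group carried on that ring. It is within the scatter. Compound 1 and compound 2 carry no group at that place on their rings and still sit close to compound 3 in this assay, so the 4-methylbenzyl of compound 3 appears to bring little. On that basis compound 4 is expected to stay in the same region, with a step of a 2.0-fold higher number from compound 3 to compound 4 (0.30 log units; within the scatter) that should not pass beyond the scatter. The estimate for compound 4 is 0.4 nM, within a range from 0.15 nM to 1.2 nM.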

Compound 4, inhibition constant: 2.4 nM
Estimate against measurement, compound 4: 6.0-fold (0.78 log units) below; the whole stated range lies below it.
By their numbers in this assay, from the lowest: compounds 3, 2 and 1 (each within the scatter of the next, the first and the last beyond it); then compound 4.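

In this assay, within the data shown here, this saturated ring carbon is not indifferent to what it carries: with methoxy in place of 4-methylbenzyl there is a 12-fold higher number from compound 3 to compound 4 (1.08 log units; beyond the scatter), a large step at a place where the earlier compounds gave no sign of one. Methoxy also stands apart from the rings with no group at that place, with an 8.0-fold higher number from compound 2 to compound 4 (0.90 log units; beyond the scatter) and a 4.0-fold higher number from compound 1 to compound 4 (0.60 log units; beyond the scatter), so among these compounds the change reads as more than the loss of 4-methylbenzyl: the methoxy compound sits beyond the scatter from all three others, while a small group here is not simply equivalent to having none. Nothing on hand accounts for this result.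

The compounds shown leave open whether the step follows the oxygen of methoxy or the smaller size of the group, and an ethyl or a benzyloxy on the same ring carbon would help to separate the two. Also open, from the compounds shown here alone, is where the plain piperidin-1-yl ring, with only hydrogen at this place, would stand against compound 3 and compound 4.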